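Chloro to methoxy on two indolinone cores

This account rests on a few compounds, and the source may have more. Where it says the series, first, only, none or still open, it means among the compounds named here.

Measured so far:
Compound 1, `COc1cc2c(/C=C3/C(=O)Nc4ccc(Cl)cc43)c(Cl)n(Cc3cc(OC)c(OC)c(OC)c3)c2cc1C`, gives 1780 nM in a functional assay on cells (Cancer cell lines, Homo sapiens) for cytotoxicity, with a stated time of 48 h; on this read-out lower numbers stand for stronger inhibition of growth and higher numbers for weaker inhibition of growth.
Compound 2, `COc1ccc2c(c1)/C(=C\c1c(Cl)n(Cc3cc(OC)c(OC)c(OC)c3)c3cc(C)c(OC)cc13)C(=O)N2`, gives 14500 nM in this assay.
Compound 3, `COc1c(/C=C2/C(=O)Nc3ccc(Cl)cc32)c2ccccc2n1-c1ccccc1`, gives 9330 nM in this assay.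

Compound 1 and compound 2 differ in one place, (methoxy in place of chloro on an aromatic carbon), and this change made an 8.1-fold higher number from compound 1 to compound 2 (0.91 log units; beyond the scatter). Compound 3 sits on a different core; how the two cores differ is not broken down here. Compound 4, `COc1ccc2c(c1)/C(=C\c1c(OC)n(-c3ccccc3)c3ccccc13)C(=O)N2`, carries the same change on the core of compound 3, (methoxy in place of chloro on an aromatic carbon), at a place described in the same words. For the measured compounds named here, only the single measured step is available to guide what to expect. Compound 4 is expected to give about 45000 nM in this assay, somewhere between 12000 nM and 150000 nM. That rests on an expected 4.8-fold higher number from compound 3 to compound 4 (0.68 log units; beyond the scatter), set beside the measured 8.1-fold higher number from compound 1 to compound 2 (0.91 log units; beyond the scatter), with a wider range because the change moves to another core.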

Compound 4, concentration for 50% growth inhibition: 2630 nM
Beside the measured number, compound 4's estimate is 17-fold (1.23 log units) above it; measured number outside the range, below it.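

In this assay, putting methoxy in place of chloro gave a 3.5-fold lower number from compound 3 to compound 4 (0.55 log units; beyond the scatter), so on this core the change goes with stronger inhibition of growth. On the core of compound 1 the same change went the opposite way, and the two results clearly differ: the same change on two cores in this assay, an 8.1-fold higher number (0.91 log units; beyond the scatter) from compound 1 to compound 2 and a 3.5-fold lower number (0.55 log units; beyond the scatter) from compound 3 to compound 4, 29-fold (1.46 log units) apart, beyond the scatter of two such steps

Within these four compounds, then, the effect of this change cannot simply be carried from one core to the other, though two pairs do not show which difference between the cores matters or how the change would behave on a third core. The compounds shown leave open how another group, such as an amine or a carboxylic acid, would fare at this place on either core.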